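A few compounds are considered here, and "the series" means these few. Any claim that something is new, unique, unknown or untested is made for them only; others in the source may bear on it.

Compound 1 `O=C(Nc1ccccc1)C1CCN(C/C=C/c2ccccc2)CC1`: 90900 nM
Compound 2 `CCCc1ccc(NC(=O)C2CCN(C/C=C/c3ccccc3)CC2)cc1`: 9410 nM
Compound 3 `O=C(Nc1cccc(F)c1)C1CCN(C/C=C/c2ccccc2)CC1`: 51100 nM

All three compounds were tested in a functional assay on HepG2 cells (Homo sapiens) for inhibition, read by MTT assay, with a stated time of 72 h; on this read-out lower numbers stand for stronger inhibition and higher numbers for weaker inhibition. Compound 3 sits with compound 1 at the high end of these numbers, and the fluoro in place of hydrogen gave a 1.8-fold lower number from compound 1 to compound 3 (0.25 log units; within the scatter). The propyl-bearing member stands apart, with a 5.4-fold higher number from compound 2 to compound 3 (0.73 log units; beyond the scatter).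

Compound 4 `O=C(Nc1ccccn1)C1CCN(C/C=C/c2ccccc2)CC1` has not yet been measured. It carries pyridin-2-yl in place of 3-fluorophenyl on an amide-type nitrogen. Among the measured compounds shown here, no measured step makes this exchange directly. The larger measured change came with a propyl, at a 9.7-fold lower number from compound 1 to compound 2 (0.98 log units; beyond the scatter), and compound 4 has no propyl. The fluoro step, at a 1.8-fold lower number from compound 1 to compound 3 (0.25 log units; within the scatter), gives the closer guide, so no change beyond the scatter is expected in this assay, although the data do not test the ring nitrogen. The expected step is a 1.4-fold higher number from compound 3 to compound 4 (0.14 log units; within the scatter). Compound 4 is estimated at 70000 nM, with an expected range from 25000 nM to 200000 nM.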

Compound 4, half-maximal inhibitory concentration: 51100 nM
Beside the measured number, compound 4's estimate is 1.4-fold (0.14 log units) above it; measured number inside the range.
By their numbers in this assay, from the lowest: compound 2; then compounds 3, 4 and 1 (each within the scatter of the next).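

In this assay pyridin-2-yl on the amide-type nitrogen, the only ring here with a hetero atom and a hydrogen-bond acceptor, gives no change at the digits printed from compound 3 to compound 4 (within the scatter) against 3-fluorophenyl and a 1.8-fold lower number from compound 1 to compound 4 (0.25 log units; within the scatter) against phenyl. Against 4-propylphenyl the same group gives a 5.4-fold higher number from compound 2 to compound 4 (0.73 log units; beyond the scatter) and so falls in with the other two rings. At this place, then, a ring nitrogen shifts the number no more than the scatter allows, and compound 2 alone stands apart from the other three compounds.

Going by these compounds, whether an amine, a carboxylic acid or a chain longer than propyl on this ring would move the number remains open. So does whether propyl on the pyridin-2-yl ring would act as it does on the phenyl ring. Nothing available here explains these results.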